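Sulfamoyl returns with a ring fluorine on the pendant phenyl

The source may report more compounds than this note shows. Statements on the series, on what has been measured and on what is new or still open speak of the compounds shown alone.

Among the measured compounds shown here, compound 2 `CCCS(=O)(=O)Nc1ccc(F)c(C(=O)c2n[nH]c3ncc(-c4ccc(NS(C)(=O)=O)cc4)cc23)c1F` gives 16% in an assay for binding affinity to dual specificity mitogen-activated protein kinase kinase 4 (Homo sapiens), read by KINOMEscan, tested at 10 nM (on this read-out higher numbers stand for a weaker effect at the one concentration tested and lower numbers for a stronger effect), the higher of the two numbers so far. For the measured compounds named here, compound 1 `CCCS(=O)(=O)Nc1ccc(F)c(C(=O)c2n[nH]c3ncc(-c4ccc(S(N)(=O)=O)cc4)cc23)c1F` gives 5.1% in this assay; the change a number 10.9 percentage points higher from compound 1 to compound 2 (beyond the scatter) is the only step measured. Compound 3 `CCCS(=O)(=O)Nc1ccc(F)c(C(=O)c2n[nH]c3ncc(-c4ccc(S(N)(=O)=O)cc4F)cc23)c1F` follows from compound 2 by 2-fluoro-4-sulfamoylphenyl in place of 4-(methanesulfonamido)phenyl on an aromatic carbon. The sulfamoyl group re-enters. Going by the values given here, the step of a number 10.9 percentage points higher from compound 1 to compound 2 (beyond the scatter) bears on this run in reverse, while the added fluorine on the phenyl has no measured counterpart. A fall of about that size is expected, a number 10 percentage points lower from compound 2 to compound 3 (within the scatter). Compound 3 is estimated at 6%, within 2% to 15%.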

Compound 3, a percentage reported as activity, at one concentration (the size of the read-out at that concentration, not a potency): 9.4%
For compound 3 the middle estimate is 3.4 percentage points below the measured one; the measured number falls inside the stated range.
By their numbers in this assay, from the lowest: compounds 1, 3 and 2 (each within the scatter of the next, the first and the last beyond it).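

Fluoro in place of hydrogen on the phenyl gives a number 4.3 percentage points higher from compound 1 to compound 3 (within the scatter), so in this assay this ring takes a fluorine with no readable change. 2-Fluoro-4-sulfamoylphenyl in place of 4-(methanesulfonamido)phenyl gives a number 6.6 percentage points lower from compound 2 to compound 3 (within the scatter), so with the fluorine present, the exchange of these groups no longer gives a step beyond the scatter. No supporting data bear on the reason for either step. Open, going by these compounds, is whether an amine or a carboxylic acid in place of sulfamoyl on this phenyl would stay within the scatter of compound 1. Chloro in place of the ring fluorine is equally open.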